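This account rests on a few compounds, and the source may have more. Where it says the series, first, only, none or still open, it means among the compounds named here.

Within the data shown here, compound 2 `Cn1cccc1C(=O)/C=C/c1ccc2c(c1)B(O)OC2` stands at the top of the two numbers measured so far in a functional assay on SK-OV-3 cells (Homo sapiens) for cytotoxicity, read by MTT assay, with a stated time of 48 h; on this read-out higher numbers stand for weaker inhibition and lower numbers for stronger inhibition: compound 2 gives 93600 nM, whereas compound 1 `O=C(/C=C/c1ccc2c(c1)B(O)OC2)c1cccnc1` gives 18500 nM. Among the measured compounds shown here, the gap between them is the single measured step, a 5.1-fold higher number from compound 1 to compound 2 (0.70 log units; beyond the scatter), which arose from swapping the ring on the carbonyl carbon. Compound 3 `O=C(/C=C/c1ccc2c(c1)B(O)OC2)c1ccc(F)cc1` continues with a change at that same place: 4-fluorophenyl in place of 1-methyl-1H-pyrrol-2-yl on a carbonyl carbon. For the measured compounds named here, the only step that bears on this move is a 5.1-fold higher number from compound 1 to compound 2 (0.70 log units; beyond the scatter), and it shows that exchanging the ring on the carbonyl carbon can shift the number beyond the scatter. Compound 1, which has the lower number, also carries a six-membered ring there, so a fall in the number is expected for compound 3, though its size is uncertain. Compound 3 is estimated at 25000 nM, with a range of 8000 nM to 80000 nM. The expected step is a 3.7-fold lower number from compound 2 to compound 3 (0.57 log units; beyond the scatter).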

Compound 3, half-maximal inhibitory concentration: 1400 nM
Estimate against measurement, compound 3: 18-fold (1.25 log units) above, outside the stated range (below it).
By their numbers in this assay, from the lowest: compound 3; then compound 1; then compound 2.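

In this assay the ring on the carbonyl carbon carries far more weight than the first exchange suggested: 4-fluorophenyl gives a 67-fold lower number from compound 2 to compound 3 (1.83 log units; beyond the scatter) and also a 13-fold lower number from compound 1 to compound 3 (1.12 log units; beyond the scatter) and so brings the lowest number of the three. The second of these steps shows that a six-membered ring at this place does not by itself fix the number, since pyridin-3-yl and 4-fluorophenyl are both six-membered aromatic rings and still stand far apart. No measurement shown here explains why these rings differ so much.

From the compounds shown here alone, whether the gain belongs to the fluorine or to the carbon-only ring stays open. A plain phenyl, a 4-chlorophenyl or a 4-methoxyphenyl on the same carbonyl carbon would help separate the two.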